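A few compounds are considered here, and "the series" means these few. Any claim that something is new, unique, unknown or untested is made for them only; others in the source may bear on it.

Compound 2, `COc1ccc(C(C)Sc2nc3c(cnn3C)c(=O)n2-c2ccccc2)cc1`, in an assay on isolated protein for inhibition of retinal dehydrogenase 2 (Homo sapiens), tested at 5 uM (on this read-out lower numbers stand for less inhibition and higher numbers for more inhibition at the one concentration tested (going by the name of the read-out)), gives 41%. Compound 1, `CC(Oc1nc2c(cnn2C)c(=O)n1-c1ccccc1)c1ccccc1`, in this assay gives 42%; the two numbers lie within the scatter of each other, so compound 2 stands as one of two closely similar readings rather than apart from compound 1. Compound 3, `CC(Sc1nc2c(cnn2C)c(=O)n1-c1ccccc1)c1ccncc1`, is not yet measured; against compound 2 the change is pyridin-4-yl in place of 4-methoxyphenyl on a saturated chain carbon bound to a saturated chain carbon and a sulfur. Among the compounds with values here, no measured pair isolates this exchange, so nothing supports a step beyond the scatter, and the expected step from compound 2 to compound 3 is a number 3 percentage points lower from compound 2 to compound 3 (within the scatter). Compound 3 is therefore estimated at 38% in this assay, within a range from 20% to 56%.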

Compound 3, a percentage reported as inhibition, at one concentration (the size of the read-out at that concentration, not a potency): 69%
Estimate against measurement, compound 3: 31 percentage points below; measured number outside the range, above it.
By their numbers in this assay, from the lowest: compounds 2 and 1 (each within the scatter of the next); then compound 3.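

In this assay, pyridin-4-yl in place of 4-methoxyphenyl on a saturated chain carbon bound to a saturated chain carbon and a sulfur gives a number 28 percentage points higher from compound 2 to compound 3 (beyond the scatter). Within the data shown here, this position therefore responds to the exchange of its aromatic ring, which no earlier pair could show. No evidence on hand accounts for the step.

The compounds shown leave open whether the step follows from the ring nitrogen or from the loss of the methoxy group. A plain phenyl or a pyridin-3-yl at this place would help separate the two.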